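The source may report more compounds than this note shows. Statements on the series, on what has been measured and on what is new or still open speak of the compounds shown alone.

Series notes. Three close analogues of a shared core differ only in the aryl group on the amide-type nitrogen. Compound 1 `O=C(COc1ccc2cc(/C=C3/SC(=O)NC3=O)ccc2c1)Nc1ccc(Cl)c(Cl)c1` carries a 3,4-dichlorophenyl group, compound 2 `O=C(COc1ccc2cc(/C=C3/SC(=O)NC3=O)ccc2c1)Nc1c(F)cc(F)cc1Br` a 2-bromo-4,6-difluorophenyl group, and compound 3 `O=C(COc1ccc2cc(/C=C3/SC(=O)NC3=O)ccc2c1)Nc1ccc(Br)c(Br)c1` a 3,4-dibromophenyl group. In an assay on isolated protein for inhibition of histone deacetylase 8 (Homo sapiens), with a stated time of 1 h (on this read-out higher numbers stand for weaker inhibition and lower numbers for stronger inhibition), compound 1 returns only the assay limit, > 50000 nM. In this assay compound 2 likewise returns only a limit, > 50000 nM. Compound 3 too gives only a limit in this assay, > 50000 nM. Because of the limit of > 50000 nM in this assay, at which 3 of the 3 values shown sit, the steps a step that the two limits leave unreadable from compound 1 to compound 2, a step that the two limits leave unreadable from compound 1 to compound 3 and a step that the two limits leave unreadable from compound 2 to compound 3 cannot be sized. Compound 3 thus stands at the limit together with the other two, with nothing separating them.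

Compound 4 `O=C(COc1ccc2cc(/C=C3/SC(=O)NC3=O)ccc2c1)Nc1ccc(Br)cc1` is the next member, still to be measured in this assay. The change from compound 3 is hydrogen in place of bromo on an aromatic carbon. All three measured steps concern the same aryl group and all were left unreadable; no readable step in this assay exists for comparison. The expected step is a step that the limit leaves unreadable from compound 3 to compound 4, no readable change. The estimate for compound 4 in this assay is 80000 nM, between 20000 nM and 300000 nM.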

Compound 4, half-maximal inhibitory concentration: 16000 nM
Estimate against measurement, compound 4: 5.0-fold (0.70 log units) above; the whole stated range lies above it.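

In this assay, among these compounds, hydrogen in place of bromo on an aromatic carbon, taking 3,4-dibromophenyl to 4-bromophenyl, gives the first step that can be sized in one direction: an at least 3.1-fold lower number from compound 3 to compound 4 (0.49 log units; beyond the scatter). The 4-bromophenyl group also separates from the other two aryl groups, with an at least 3.1-fold lower number from compound 2 to compound 4 (0.49 log units; beyond the scatter) and an at least 3.1-fold lower number from compound 1 to compound 4 (0.49 log units; beyond the scatter), so this aryl position can change the read-out, whereas the steps among compounds 1, 2 and 3 cannot be read. From the compounds shown here alone, each of the three new steps has only a lower bound on its size, and its full size remains unknown because of this limit: the limit of > 50000 nM in this assay, at which 3 of the 4 values shown sit.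

Going by these compounds, it remains open whether the remaining bromo in compound 4 contributes to the read-out. A methoxy or a nitrile in its place would test this.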